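A few compounds are considered here, and "the series" means these few. Any claim that something is new, unique, unknown or untested is made for them only; others in the source may bear on it.

In an ADME assay on HEK293 cells (Homo sapiens) for cytotoxicity, with a stated time of 72 h (a lower number here means that less compound is needed, a higher number that more compound is needed for the effect), compound 1 (`C=C[C@@](C)(/C=C/c1ccc(OC)cc1)CCC=C(C)C`) gives > 36600 nM as a limit of the assay. Compound 2 (`C=C[C@@](C)(/C=C/c1ccc(Nc2ccc(F)cc2)cc1)CCC=C(C)C`) gives > 36600 nM as a limit too, so it has no numerical position in the series. Evidence so far amounts to the limit of > 36600 nM in this assay, at which 2 of the 2 values shown sit, and nothing more. The next change leads to compound 3 (`C=C[C@@](C)(/C=C/c1ccc(Nc2cc(F)c(F)cc2F)cc1)CCC=C(C)C`), with 2,4,5-trifluorophenyl in place of 4-fluorophenyl on a nitrogen on an aromatic ring and no other difference. Among the measured compounds shown here, the only measured step, a step that the two limits leave unreadable from compound 1 to compound 2, concerns another place and has no readable size, so it offers no magnitude to carry over. In this assay the expected step of a number no higher from compound 2 to compound 3 (the limit leaves the size open) is none beyond the scatter, and another limit is the likeliest report. For compound 3 the estimated value is 36600 nM, with an expected range from 15000 nM to 60000 nM in this estimate.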

Compound 3, half-maximal effective concentration: > 36600 nM
Compound 3: a limit, no number; the forecaster's own chance of this, stated with the estimate: 75%; the middle value sits exactly at the limit.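

Compound 2 and compound 3 are both reported only as limits in this assay, so no step can be read between them. The compounds shown leave open whether any change on the shared core would bring the half-maximal effective concentration to a measurable number.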